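Thiazolidinone series: aryl swap on the ring nitrogen

The source may report more compounds than this note shows. Statements on the series, on what has been measured and on what is new or still open speak of the compounds shown alone.

Measured compounds:
Compound 1, `O=C(NCCCCc1ccccc1)c1cccc(C2OCC(=O)N2c2cccc(F)c2)c1`, 87%
Compound 2, `CCN1C(=O)CSC1c1cccc(C(=O)NCCCCc2ccccc2)c1`, 0%
Compound 3, `COc1c(F)cccc1N1C(=O)CSC1c1cccc(C(=O)NCCCCc2ccccc2)c1`, 12%

In a functional assay on HOS-TE85 cells (Homo sapiens) for inhibition, read by CCK-8 assay, with a stated time of 72 h, tested at 1 uM (a lower number here means less inhibition, a higher number more inhibition at the concentration tested (going by the name of the read-out)), compound 3 stands second highest of the three numbers. Among the measured compounds shown here, its nearest neighbour is compound 2, with a number 12 percentage points higher from compound 2 to compound 3 (beyond the scatter); the furthest is compound 1, which gives 87%, whereas compound 3 gives 12%, though that pair differs in more than one place and no single step describes it.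

Compound 4, `O=C(NCCCCc1ccccc1)c1cccc(C2SCC(=O)N2c2ccccc2F)c1`, has not been measured. It differs from compound 3 as follows: 2-fluorophenyl in place of 3-fluoro-2-methoxyphenyl on an amide-type nitrogen in a ring.

For the measured compounds named here, the only measured step, from compound 2 to compound 3, swaps an ethyl for an aryl group on the same ring nitrogen and is modest in size; no measured step exchanges one aryl group for another there, so it bears only loosely on the new change. A step of similar or smaller size is therefore expected for compound 4, in either direction, most likely within or just beyond the scatter: a number 10 percentage points higher from compound 3 to compound 4 (within the scatter). Compound 4 is estimated at 22%, between 0% and 58%.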

Compound 4, a percentage reported as inhibition, at one concentration (the size of the read-out at that concentration, not a potency): 95%
Compound 4: middle estimate off by 73 percentage points, on the low side, outside the stated range (above it).
By their numbers in this assay, from the lowest: compound 2; then compound 3; then compounds 1 and 4 (each within the scatter of the next).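

Working notes: on the amide-type nitrogen in the ring, the choice of aryl group governs the result in this assay, with 2-fluorophenyl in place of 3-fluoro-2-methoxyphenyl giving a number 83 percentage points higher from compound 3 to compound 4 (beyond the scatter) as a large step. An aryl group alone therefore does not account for the outcome: 2-fluorophenyl in place of ethyl gives a number 95 percentage points higher from compound 2 to compound 4 (beyond the scatter) as a large step, whereas 3-fluoro-2-methoxyphenyl in place of ethyl gave only a modest one. No supporting data bear on why these two aryl groups read so differently.

The change from 3-fluoro-2-methoxyphenyl to 2-fluorophenyl alters the methoxy group and the fluorine together, so the part each plays stays unresolved. Also open, on these data alone, is how a plain phenyl or a 2-chlorophenyl would read on this nitrogen.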